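The source may report more compounds than this note shows. Statements on the series, on what has been measured and on what is new or still open speak of the compounds shown alone.

Three compounds have been measured so far:

Compound 1, `COc1ccc(/C=C/C=N/NC(=O)c2ccc(C(C)(C)C)cc2)cc1`: in a physicochemical assay, read by spectrophotometry, with a stated time of 60 min, tested at 1000 uM (on this read-out lower numbers stand for a weaker effect and higher numbers for a stronger effect at the one concentration tested), compound 1 gives 7.1%.
Compound 2, `COc1ccc(/C=C/C=N/NC(=O)c2ccc(O)cc2)cc1`: in this assay compound 2 gives 2.8%.
Compound 3, `CC(C)(C)c1ccc(C(=O)N/N=C/c2cc(O)cc(O)c2)cc1`: in this assay compound 3 gives 31.3%.

Compound 1 and compound 2 share one core and differ in a single place: hydroxy in place of tert-butyl on an aromatic carbon. Across that change the read-out moved by a number 4.3 percentage points lower from compound 1 to compound 2 (within the scatter), so the two numbers cannot be told apart. Compound 3 is built on a different core; how its core differs from that of compound 1 is not broken down here. Among the three, compound 3 gives the highest number, and its distance from both compound 1 and compound 2 is beyond the scatter.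

Compound 4, `O=C(N/N=C/c1cc(O)cc(O)c1)c1ccc(O)cc1`, has not yet been measured in this assay. It arises from compound 3 by the same change that turns compound 1 into compound 2: hydroxy in place of tert-butyl on an aromatic carbon. The place where the groups are exchanged is described in the same words for both pairs, so the change is the same one, only applied to another core. Going by the values given here, since the one earlier example of this exchange gave a number 4.3 percentage points lower from compound 1 to compound 2 (within the scatter), a change within the scatter, the expected step from compound 3 to compound 4 is also small, estimated as a number 4.3 percentage points lower from compound 3 to compound 4 (within the scatter). This expectation rests on a single precedent, and the core of compound 3 has not yet been tested with this exchange, so the range is kept wide. Compound 4 is estimated to give 27% in this assay, with the likely range running from 14% to 40%.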

Compound 4, a percentage reported as inhibition, at one concentration (the size of the read-out at that concentration, not a potency): 34.2%
Compound 4: the middle estimate sits 7.2 percentage points below what was measured; the range from low to high includes it.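

In this assay, the exchange of tert-butyl for hydroxy now has two examples, and each stays within the usual scatter of repeated measurements: a number 4.3 percentage points lower from compound 1 to compound 2 (within the scatter) on one core, and a number 2.9 percentage points higher from compound 3 to compound 4 (within the scatter) on the other. This shows that, in these two pairs, the exchange carried over from one core to the other without producing a step that can be told apart from measurement noise. Going by these compounds alone, it does not show that the two groups are interchangeable in general, since there are only two pairs, each read at a single concentration, which gives the size of an effect rather than a potency, and no measurement at hand explains why the steps stay so small.

The compounds shown leave open whether another group on that aromatic carbon, such as an amine, a carboxylic acid or a longer chain, would also stay within the scatter on both cores. They also leave open whether the exchange of tert-butyl for hydroxy would stay this small on a third core.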